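This account rests on a few compounds, and the source may have more. Where it says the series, first, only, none or still open, it means among the compounds named here.

Compound 1 `COc1cc(NC(C)CCCNC(=O)Nc2ccc(Cl)c(C(F)(F)F)c2)c2ncccc2c1`, compound 2 `COc1cc(NC(C)CCCNC(=O)NN)c2ncccc2c1` and compound 3 `COc1cc(NC(C)CCCNC(=O)NNC(=O)NCCCCCO)c2ncccc2c1` share one core and differ only in the group carried on an amide-type nitrogen at the far end of the chain. In a functional assay on L1210 cells (Mus musculus) for inhibition, read by MTT assay, with a stated time of 4 days (on this read-out lower numbers stand for stronger inhibition and higher numbers for weaker inhibition), compound 1 gives 3600 nM. For compound 2 this assay reports no number but a limit, > 250000 nM. For compound 3 this assay likewise reports only a limit, > 250000 nM. Compound 3 therefore stands at the limit of > 250000 nM in this assay, at which 2 of the 3 values shown sit, where the value of compound 2 also sits. The step of an at least 69-fold higher number from compound 1 to compound 3 (1.84 log units; beyond the scatter) is large, while the step that the two limits leave unreadable from compound 2 to compound 3 cannot be read, because the limit of > 250000 nM in this assay, at which 2 of the 3 values shown sit, caps both ends.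

Compound 4 `COc1cc(NC(C)CCCNC(=O)NNC(=O)NCCCO)c2ncccc2c1` differs from compound 3 by hydroxy in place of 2-hydroxyethyl on a saturated chain carbon, three bonds along the chain from an amide-type nitrogen. Among the measured compounds shown here, no measured step alters the length of a hydroxyalkyl chain on its own; the only steps that bear on compound 4 are those reaching compound 3, and both end at the limit. Nothing among the three measured compounds suggests that shortening the chain would bring the value back to a readable number, so compound 4 is expected to remain at the limit as well, and the expected step is a step that the limit leaves unreadable from compound 3 to compound 4, within the scatter rather than beyond it. Compound 4 is estimated at 300000 nM, with a range from 150000 nM to 1000000 nM.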

Compound 4, half-maximal inhibitory concentration: > 250000 nM
Compound 4: no number, only a limit (the forecaster's own chance of this, stated with the estimate: 85%); the middle value does not contradict the limit.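

Where compound 3 carries 5-hydroxypentyl, compound 4 carries 3-hydroxypropyl, and in this assay compound 4 gives > 250000 nM, which is a limit and not a number. Shortening the hydroxyalkyl chain in this way therefore brings no readable value back, and set against the group 4-chloro-3-(trifluoromethyl)phenyl the change remains an at least 69-fold higher number from compound 1 to compound 4 (1.84 log units; beyond the scatter), a large step. The steps that reach compound 4 from compound 2 and from compound 3 cannot be read, because neither end of them is a number: the limit of > 250000 nM in this assay, at which 3 of the 4 values shown sit.

As far as these compounds go, how far compound 2, compound 3 and compound 4 really lie from one another stays open, and so does whether the length of the hydroxyalkyl chain has any effect of its own in this assay. Also open, from the compounds shown here alone, is whether an amine or a carboxylic acid in place of the hydroxy, or a chain carrying no hydroxy at all, would return a readable number.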